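The source may hold more compounds than are shown below. What is called first, only, known or untested is meant among the compounds shown, and "the series" means these compounds.

Measured in an ADME assay on the whole organism (Rattus norvegicus, strain Sprague-Dawley) for protein binding, read by LC-MS, with a stated time of 30 min, at a dose of 1 mg/kg by the intravenous route; a lower number here means slower removal, a higher number faster removal of the compound:
- Compound 1 `N#Cc1ccc(S(=O)(=O)[C@H]2CN(S(=O)(=O)c3ccc(C#N)cc3Cl)C[C@@]2(O)CO)cc1`: 4 mL/min/kg
- Compound 2 `N#Cc1ccc(S(=O)(=O)N2C[C@H](S(=O)(=O)c3ccc(Cl)cc3)[C@](O)(CO)C2)c(Cl)c1`: 12 mL/min/kg

Compound 2 has the higher of the two numbers, at 12 mL/min/kg. Compound 3 `N#Cc1ccc(S(=O)(=O)N2C[C@H](S(=O)(=O)c3ccc(Cl)cc3)[C@](O)(CO)C2)cn1` keeps its core and changes one group: 6-cyanopyridin-3-yl in place of 2-chloro-4-cyanophenyl on a sulfonyl sulfur. Within the data shown here, no measured step covers this swap. The nearest evidence is a 3.0-fold higher number from compound 1 to compound 2 (0.48 log units; beyond the scatter), a modest step beyond the scatter, for chloro in place of cyano on an aromatic carbon. That step lies elsewhere in the molecule, so it bears only indirectly. The present change also removes a chloro group, so a fall smaller than that step is expected, perhaps no more than the scatter. The expected step is a 1.7-fold lower number from compound 2 to compound 3 (0.23 log units; within the scatter). For compound 3 the estimated value is 7 mL/min/kg, with an expected range of 3 mL/min/kg to 15 mL/min/kg.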

Compound 3, clearance: 1.2 mL/min/kg
For compound 3 the middle estimate is 5.8-fold (0.77 log units) above the measured one; the whole stated range lies above it.
By their numbers in this assay, from the lowest: compound 3; then compound 1; then compound 2.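

On the sulfonyl sulfur whose other neighbour is the sulfonamide nitrogen in a ring, the aryl group strongly affects removal in this assay: 6-cyanopyridin-3-yl in place of 2-chloro-4-cyanophenyl gives a 10-fold lower number from compound 2 to compound 3 (1.00 log units; beyond the scatter). Among these compounds, this is the first reading at this position, since the earlier step, a 3.0-fold higher number from compound 1 to compound 2 (0.48 log units; beyond the scatter), concerned a chloro-for-cyano change elsewhere in the molecule. No measurement presented here accounts for the slower removal of compound 3.

The swap brings in a ring nitrogen and drops the chloro group at once, so the compounds shown leave open how the step divides between those two changes. They also leave open whether the nitrile of the 6-cyanopyridin-3-yl group matters to the result, and a methoxy group or an amine in its place would bear on that.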